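The compounds below may be only part of what the source reports. "The series", "measured", "known", "first", "only" and "open" are said of these compounds alone.

Measured so far in a functional assay on the whole organism (strain Wistar) for inhibition, with Rattus norvegicus as the target, read by paw edema, with stated times of 30 min and 3 h, at a dose of 100 mg/kg by the oral route; on this read-out lower numbers stand for less inhibition and higher numbers for more inhibition at the one dose given (going by the name of the read-out):
compound 1, `COc1cc(C(N)=O)nn1-c1ccccc1`: 34.3%
compound 2, `COc1cc(C(=O)Nc2cccc(C(F)(F)F)c2)nn1-c1ccccc1`: 20.9%
compound 3, `CCCCOc1cc(C(N)=O)nn1-c1ccccc1`: 26.5%

Compound 3 stands second highest of these three numbers, yet compound 2 and compound 1 both lie within the scatter of it, so no order among them can be claimed. Compound 4, `CCCCOc1cc(C(=O)NCCC)nn1-c1ccccc1`, differs from compound 3 in one place: propyl in place of hydrogen on an amide-type nitrogen. For the measured compounds named here, no measured step touches this place. Going by the values given here, the only measured step, a number 7.8 percentage points lower from compound 1 to compound 3 (within the scatter), sits elsewhere and stays within the scatter. Compound 1 and compound 2, which differ on the amide-type nitrogen, also show values within the scatter of each other. A step within the scatter is therefore expected, perhaps slightly downward: a number 2.5 percentage points lower from compound 3 to compound 4 (within the scatter). Compound 4 is estimated at 24%, ranging from 10% to 38%.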

Compound 4, a percentage reported as inhibition, in the whole organism at one dose (the size of the read-out at that dose, not a potency): 51.2%
Estimate against measurement, compound 4: 27.2 percentage points below, outside the stated range (above it).
By their numbers in this assay, from the lowest: compounds 2, 3 and 1 (each within the scatter of the next, the first and the last beyond it); then compound 4.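

In this assay, the amide-type nitrogen proves to be a place where a small chain counts: propyl in place of hydrogen there gives a number 24.7 percentage points higher from compound 3 to compound 4 (beyond the scatter) with the rest of the molecule unchanged. For the compounds shown here, the one earlier step, made on the chain bound to the oxygen, did not reach beyond the scatter. Nothing at hand explains why this change has such an effect.

Still open, on these data alone, is how a shorter chain such as ethyl, a longer chain such as hexyl, or a propyl chain ending in an amine would behave on this nitrogen. Also open, as far as these compounds go, is whether propyl there would act the same way on the core of compound 1 .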